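The source may hold more compounds than are shown below. What is called first, only, known or untested is meant among the compounds shown, and "the series" means these compounds.

Working notes on the series.

Compound 1 `Cc1nc(N)sc1S(=O)(=O)Nc1ccc(Cc2nc3c([nH]2)c(=O)n(Cc2ccccc2F)c(=O)n3CC2CC2)cc1` gives, in an assay on H4IIE cells for inhibition of phosphoenolpyruvate carboxykinase, cytosolic [GTP] (Rattus norvegicus) (a higher number here means that more compound is needed for the effect, a lower number that less compound is needed), a half-maximal effective concentration of 8200 nM. The related compound 2 `CCCCn1c(=O)n(Cc2ccccc2F)c(=O)c2[nH]c(Cc3ccc(NC(C)=O)cc3)nc21` gives 8600 nM in this assay, and the two values sit within the usual scatter of one another, so neither can be ranked ahead of the other on this evidence. Compound 3 `CCCCn1c(=O)n(Cc2ccccc2F)c(=O)c2[nH]c(Cc3ccc(NS(=O)(=O)c4cccs4)cc3)nc21` carries a further sulfonamide variant, but its entry in this assay reads "not determined" (no result reported), so it adds nothing to the spread of numbers. Compound 1 is therefore one of two nearly identical readings, both in the high-micromolar region.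

Compound 4 `Cc1noc(C)c1S(=O)(=O)Nc1ccc(Cc2nc3c([nH]2)c(=O)n(Cc2ccccc2F)c(=O)n3CC2CC2)cc1` is the next member to be measured. It differs from compound 1 only at the sulfonyl group: 3,5-dimethyl-1,2-oxazol-4-yl in place of 2-amino-4-methyl-1,3-thiazol-5-yl on a sulfonyl sulfur. Among the measured compounds shown here, no pair of measured compounds separates this change from others, so there is no measured step to lean on. The expectation is that this aromatic exchange keeps compound 4 close to compound 1, with no step beyond the scatter in either direction, giving an expected step of a 1.2-fold higher number from compound 1 to compound 4 (0.09 log units; within the scatter). On that basis compound 4 is estimated to give 10000 nM in this assay, with a plausible range from 3000 nM to 30000 nM.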

Compound 4, half-maximal effective concentration: 3400 nM
Compound 4: middle estimate off by 2.9-fold (0.47 log units), on the high side; the measured number falls inside the stated range.
By their numbers in this assay, from the lowest: compound 4; then compounds 1 and 2 (each within the scatter of the next).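

Working notes on the sulfonyl position: in this assay, 3,5-dimethyl-1,2-oxazol-4-yl in place of 2-amino-4-methyl-1,3-thiazol-5-yl gives a 2.4-fold lower number from compound 1 to compound 4 (0.38 log units; beyond the scatter), the first measured step in the series, so the group on the sulfonyl sulfur can shift the reading beyond the scatter, though only modestly. The step arises between two groups that share a count of 7 heavy atoms and are each one five-membered aromatic ring with 2 hetero atoms, while the leaving group has 1 hydrogen-bond donor and 3 hydrogen-bond acceptors and the entering group has 0 hydrogen-bond donors and 2 hydrogen-bond acceptors. No measurement at hand explains the step, and this single pair cannot assign it to any one difference between the two groups.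

Still open, going by these compounds, is whether the step belongs to the loss of the amino group or to the exchange of the ring as a whole, which a 4-methyl-1,3-thiazol-5-yl group on the same sulfur would help to separate. Also open, on these data alone, is how a plain phenyl or a simple methyl on the sulfonyl sulfur would read on the shared core.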